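The source may report more compounds than this note shows. Statements on the series, on what has been measured and on what is new or still open speak of the compounds shown alone.

In a functional assay on T47D cells (Homo sapiens) for cytotoxicity, read by MTT assay, with a stated time of 2 days (on this read-out higher numbers stand for weaker inhibition and lower numbers for stronger inhibition), compound 1 `Cc1ccc2nc(-c3ccccc3C(F)(F)F)[nH]c(=O)c2c1` gives > 50000 nM, which is a limit of the assay and not a number. Compound 2 `Cc1ccc2nc(-c3cccc4ccccc34)[nH]c(=O)c2c1` gives > 50000 nM in this assay, and this too is a limit. Among the measured compounds shown here, compound 2 therefore has no exact value, and its one neighbouring reading offers no number for comparison.

Compound 3 `CCN(CC)c1ccc2nc(-c3cccc4ccccc34)[nH]c(=O)c2c1` keeps the rest of compound 2 but has diethylamino in place of methyl on an aromatic carbon. For the measured compounds named here, no measured pair shows what this kind of change does in this assay, so the expectation here is only a cautious judgement. Any number measured for compound 3 would have to mean stronger inhibition than the limit shown by compound 2, > 50000 nM. A clear move in that direction is expected, although compound 3 could also stay at the limit. The expected change is an at least 10-fold lower number from compound 2 to compound 3 (1.00 log units; beyond the scatter), and its size is very uncertain. The estimate for compound 3 is 5000 nM, with an expected range from 400 nM to 50000 nM.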

Compound 3, half-maximal inhibitory concentration: 2690 nM
The estimate for compound 3 lay 1.9-fold (0.27 log units) above the measured number; the measured number falls inside the stated range.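

In this assay, among the compounds shown here, a change at this one position on the aromatic carbon, with diethylamino in place of methyl and the rest of the molecule kept, turns a reading at the limit into an exact number, which is the one thing the earlier compounds could not provide: the step is an at least 18-fold lower number from compound 2 to compound 3 (1.26 log units; beyond the scatter). Compound 2 gives > 50000 nM, and that value is a limit of the assay. The position therefore matters for this cell read-out, yet the size of the step can be stated only from one side because of where most of the readings sit: the limit of > 50000 nM in this assay, at which 2 of the 3 values shown sit.

A single pair cannot separate the contribution of the nitrogen from that of the two ethyl chains, so a primary amine, dimethylamino or a plain butyl chain on the same carbon would be needed to tell them apart. As far as these compounds go, it also remains open whether diethylamino has a similar effect when the trifluoromethyl-bearing ring of compound 1 replaces the ring system carried by compound 3, or whether this step belongs to that one pair alone.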